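Replacing the core chloro of compound 2 with hydroxyethoxy

A few compounds are considered here, and "the series" means these few. Any claim that something is new, unique, unknown or untested is made for them only; others in the source may bear on it.

The three measured compounds share one core and differ in the substituent on the phenyl ring. Compound 2 `COc1ccccc1Oc1c(N)nc(-c2ccc(Br)cc2)nc1Cl` gives 63 nM in a functional assay on A-375 cells (Homo sapiens) for cytotoxicity, read by CCK-8 assay, with a stated time of 24 h (a lower number here means a stronger inhibitor, a higher number a weaker inhibitor), the lowest of the two numbers measured. Compound 3 `COc1ccccc1Oc1c(N)nc(-c2ccc(I)cc2)nc1Cl` gives 480 nM in this assay, and the step of a 7.6-fold higher number from compound 2 to compound 3 (0.88 log units; beyond the scatter) lies beyond the scatter. Compound 1 `COc1ccc(-c2nc(N)c(Oc3ccccc3OC)c(Cl)n2)cc1` in this assay gives a limit, > 80000 nM (the limit of > 80000 nM in this assay, at which 1 of the 3 values shown sits). From compound 1 the steps of an at least 1200-fold lower number from compound 1 to compound 2 (3.10 log units; beyond the scatter) and an at least 160-fold lower number from compound 1 to compound 3 (2.22 log units; beyond the scatter) are both large.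

Compound 4 `COc1ccccc1Oc1c(N)nc(-c2ccc(Br)cc2)nc1OCCO` differs from compound 2 by 2-hydroxyethoxy in place of chloro on an aromatic carbon. On these data alone, all three measured steps concern the phenyl substituent; none alters the chloro on the core, so none bears directly on this change, and its direction is untested. The expected step of a 6.3-fold higher number from compound 2 to compound 4 (0.80 log units; beyond the scatter) is therefore set modest, with a wide range. For compound 4 the number in this assay is expected near 400 nM, between 60 nM and 3000 nM.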

Compound 4, half-maximal inhibitory concentration: 10300 nM
Compound 4: middle estimate off by 26-fold (1.41 log units), on the low side; measured number above the stated range.
By their numbers in this assay, from the lowest: compound 2; then compound 3; then compound 4. At a limit, above all of these: compound 1.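

The chloro on the shared core is a position that responds strongly: with the 4-bromophenyl group held constant, the step in this assay is a 160-fold higher number from compound 2 to compound 4 (2.21 log units; beyond the scatter). Going by these compounds alone, the earlier steps all concerned the phenyl substituent, so this is the first evidence that a change at the core alone can move the number by a large step, and here the direction is upward. No measurement shown gives a cause for this step.

A single replacement cannot separate the loss of chloro from the effect of the entering 2-hydroxyethoxy chain. On these data alone, a methoxy group, a 2-aminoethoxy chain or a longer chain ending in a carboxylic acid in place of chloro would test this, and whether the step carries over to the iodo substituent of compound 3 remains open.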